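Replacing Isobutyl with 3-Fluorophenyl: Cytotoxicity Outlook

The source may hold more compounds than are shown below. What is called first, only, known or untested is meant among the compounds shown, and "the series" means these compounds.

Three compounds on a shared core have been examined so far. For the measured compounds named here, compound 1 `CC(C)(C)CCN1C(=O)C(C2=NS(=O)(=O)c3cc(NS(C)(=O)=O)ccc3N2)=C(O)C2CCCCCCC21` is the first of them; in an ADME assay on Huh-7 cells (Homo sapiens) for cytotoxicity, with a stated time of 72 h (on this read-out higher numbers stand for lower toxicity in this test and lower numbers for higher toxicity in this test), compound 1 gives "not determined" (no result reported). Compound 2 `CC(C)CCN1C(=O)C(C2=NS(=O)(=O)c3cc(NS(C)(=O)=O)ccc3N2)=C(O)C2CCCC21` is the second. In this assay compound 2 gives only the limit > 1000 nM. Compound 3 `CC(C)CCN1C(=O)C(C2=NS(=O)(=O)c3cc(NS(C)(=O)=O)ccc3N2)=C(O)[C@H]2CCC[C@H]21` has the same atoms and bonds as compound 2 but is drawn with defined configuration at two saturated ring carbons. In this assay compound 3 likewise gives the limit > 1000 nM. The step that the two limits leave unreadable from compound 2 to compound 3 cannot be read because the limit of > 1000 nM in this assay, at which 2 of the 3 values shown sit, and because of the fact that one of compounds 2 and 3 is drawn with a defined configuration and the other without, at the place where they differ. Compound 2 therefore stands on a limit, one further value is a limit, and the remaining entry carries no number at all.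

Compound 4 `CS(=O)(=O)Nc1ccc2c(c1)S(=O)(=O)N=C(C1=C(O)C3CCCC3N(Cc3cccc(F)c3)C1=O)N2` differs from compound 2 by 3-fluorophenyl in place of isobutyl on a saturated chain carbon bound to an amide-type nitrogen in a ring. Going by the values given here, no measured step touches this group, and the one step on record is unreadable. Both measured values sit at the same limit, so compound 4 is expected to sit there as well, with an expected step that the limit leaves unreadable from compound 2 to compound 4 that is not beyond the scatter. The estimate for compound 4 is 2000 nM, between 1000 nM and 10000 nM.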

Compound 4, half-maximal cytotoxic concentration: > 33000 nM
Compound 4 ended at the assay's limit (the forecaster's own chance of this, stated with the estimate: 80%); at least 16-fold (1.21 log units) between middle value and limit.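

In this assay compound 4 gives > 33000 nM, which is a limit of the assay. Compound 2 also stands on a limit, and the step from compound 2 to compound 4 cannot be read. The compounds shown leave open whether 3-fluorophenyl in place of isobutyl changes this read-out at all.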